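This account rests on a few compounds, and the source may have more. Where it says the series, first, only, none or still open, it means among the compounds named here.

Three compounds share one core and differ only in the group attached to one aromatic carbon of that core. Compound 1 `COc1cccc(CNCCCNc2ccnc3cc(-c4ccc(C(F)(F)F)cc4)ccc23)c1O` gives 2210 nM in an ADME assay on HepG2 cells (Homo sapiens) for cytotoxicity, read by luminescence, CellTiter-Glo and ATP content, with a stated time of 72 h; on this read-out lower numbers stand for an effect already at smaller amounts and higher numbers for an effect only at larger amounts of compound; compound 2 `COc1cccc(CNCCCNc2ccnc3cc(Oc4ccc(C(C)(C)C)cc4)ccc23)c1O` gives 1500 nM; compound 3 `COc1cccc(CNCCCNc2ccnc3cc(Cc4ccc(F)cc4Cl)ccc23)c1O` gives 2350 nM. Compound 3 has the highest of the three numbers, yet its distance to its neighbours is small: a 1.1-fold higher number from compound 1 to compound 3 (0.03 log units; within the scatter) and a 1.6-fold higher number from compound 2 to compound 3 (0.19 log units; within the scatter), so the three compounds cannot be told apart on this read-out.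

Compound 4 `COc1cccc(CNCCCNc2ccnc3cc(Cc4cc(C)cc(C)c4)ccc23)c1O` is the next change at the same place: 3,5-dimethylphenyl in place of 2-chloro-4-fluorophenyl on a saturated chain carbon bound to an aromatic carbon. Among the compounds with values here, the steps that bear on it are the earlier swaps of the group on that aromatic carbon. All three were small: a 1.5-fold lower number from compound 1 to compound 2 (0.17 log units; within the scatter), a 1.1-fold higher number from compound 1 to compound 3 (0.03 log units; within the scatter) and a 1.6-fold higher number from compound 2 to compound 3 (0.19 log units; within the scatter). Rather different groups at this position have therefore left the cytotoxicity read-out essentially unchanged, and nothing in these three compounds points to the dimethylphenyl group behaving otherwise. The step from compound 3 to compound 4 is thus expected to be a 1.1-fold lower number from compound 3 to compound 4 (0.03 log units; within the scatter), that is, no movement beyond the scatter. On that basis compound 4 is estimated to give 2200 nM in this assay, with a plausible range from 1100 nM to 4500 nM, which it would share with the three compounds already measured.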

Compound 4, half-maximal effective concentration: 2680 nM
Compound 4: the middle estimate sits 1.2-fold (0.09 log units) below what was measured; low and high end bracket the measured number.
By their numbers in this assay, from the lowest: compounds 2, 1, 3 and 4 (each within the scatter of the next).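

Replacing 2-chloro-4-fluorophenyl with 3,5-dimethylphenyl on a saturated chain carbon bound to an aromatic carbon exchanges a ring bearing chlorine and fluorine for one bearing only carbon substituents, yet this assay shows only a 1.1-fold higher number from compound 3 to compound 4 (0.06 log units; within the scatter). Compared across the wider changes at this place, the 3,5-dimethylbenzyl group gives a 1.2-fold higher number from compound 1 to compound 4 (0.08 log units; within the scatter) and a 1.8-fold higher number from compound 2 to compound 4 (0.25 log units; within the scatter), so even the largest of these new steps stays within the usual variation between repeat measurements, and a benzyl group without halogens cannot be told apart from the three earlier groups. The data shown offer no independent measurement that could explain why this read-out stays so flat.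

From the compounds shown here alone, all four groups at this place end in an aromatic ring made only of carbon, so it remains open whether an amine or a carboxylic acid there would move the number beyond the scatter. Every change shown also sits at this one place, so the effect of a longer chain elsewhere in the shared structure remains open too.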